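A few compounds are considered here, and "the series" means these few. Any claim that something is new, unique, unknown or untested is made for them only; others in the source may bear on it.

Of the compounds shown here, two have been measured in a functional assay on U2OS cells for antagonist activity at C-X-C chemokine receptor type 3 (Homo sapiens), read by beta-arrestin recruitment; on this read-out higher numbers stand for weaker inhibition and lower numbers for stronger inhibition. Compound 1, `CCOc1ncc(-c2nc(C(F)(F)F)sc2N2CCN(C(=O)Cn3ccc4cnccc43)[C@H](C)C2)cn1`, gives 23 nM in this assay. Compound 2, `Cc1nc(C)n(CC(=O)N2CCN(c3sc(C(F)(F)F)nc3-c3cnc(OC(C)C)nc3)C[C@H]2C)n1`, gives 138 nM in this assay, the higher of the two numbers; the gap to compound 1 lies beyond the usual scatter, so compound 2 is the weaker inhibitor of the pair. Compound 3, `COc1ccc(-c2nc(C(F)(F)F)sc2N2CCN(C(=O)Cn3nc(C)nc3C)[C@H](C)C2)cn1`, has not been measured. It keeps the whole of compound 2 except for one exchange: 6-methoxypyridin-3-yl in place of 2-isopropoxypyrimidin-5-yl on an aromatic carbon of the shared core. Among the compounds with values here, no measured pair shows this exchange on its own, and compound 1 differs from compound 2 in two places at once, so the data give no direct guide to the size or direction of the step. The step from compound 2 to compound 3 is therefore estimated to be a 1.1-fold higher number from compound 2 to compound 3 (0.04 log units; within the scatter), which means no clear change beyond the scatter. Compound 3 is expected to give about 150 nM in this assay, with a likely range from 50 nM to 450 nM.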

Compound 3, half-maximal inhibitory concentration: 1170 nM
For compound 3 the middle estimate is 7.8-fold (0.89 log units) below the measured one, outside the stated range (above it).
By their numbers in this assay, from the lowest: compound 1; then compound 2; then compound 3.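

In this assay, putting 6-methoxypyridin-3-yl in place of 2-isopropoxypyrimidin-5-yl gives an 8.5-fold higher number from compound 2 to compound 3 (0.93 log units; beyond the scatter), a step beyond the scatter. This shows that the aromatic carbon of the five-membered ring is not indifferent to the group it carries, since inhibition clearly weakens while the rest of compound 2 stays the same. No measurement at hand accounts for this loss.

Going by these compounds, the exchange alters both the ring and the group on its oxygen, so it remains open which of the two changes matters; 2-methoxypyrimidin-5-yl or 6-isopropoxypyridin-3-yl at this position would separate them. On these data alone, it is also open whether the exchange would have a step of similar size with a different group on the amide side of the molecule.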